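From 2-fluorophenyl to cyclohexyl at the assay limit

The compounds below may be only part of what the source reports. "The series", "measured", "known", "first", "only" and "open" are said of these compounds alone.

Compound 1 (`O=C(NCc1ccccc1F)N1C(=O)c2ccccc2S1(=O)=O`) gives > 166 h in a physicochemical assay for pharmacokinetics (on this read-out lower numbers stand for a shorter-lived compound and higher numbers for a longer-lived compound), and that value is a limit, not a number. Compound 2 (`O=C(c1ccccc1)N1Cc2ccccc2S1(=O)=O`) gives > 166 h in this assay and that value is also a limit. Compound 1 thus stands at the limit of > 166 h in this assay, at which 2 of the 2 values shown sit, and so no order can be read between the two.

Compound 3 (`O=C(NCC1CCCCC1)N1C(=O)c2ccccc2S1(=O)=O`) carries cyclohexyl in place of 2-fluorophenyl on a saturated chain carbon bound to an amide-type nitrogen. Within the data shown here, no two measured compounds differ in one place alone, so no measured step gives a size for this change. In this assay no step beyond the usual scatter is expected, and compound 3 may well return only a limit too. The expected step (a step that the limit leaves unreadable from compound 1 to compound 3) stays within that scatter. Compound 3 is estimated at 180 h with an expected range of 90 h to 360 h around it.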

Compound 3, half-life: > 166 h
Compound 3 was reported as a limit; the forecaster's own chance of this, stated with the estimate: 70%; the middle value does not contradict the limit.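

Compound 1 and compound 3 both return only a limit in this assay, so no step can be read between them: the limit of > 166 h in this assay, at which 3 of the 3 values shown sit.

The compounds shown leave open how long any of them actually lasts in this assay, and whether cyclohexyl in place of 2-fluorophenyl changes that at all.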